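The source may hold more compounds than are shown below. What is called first, only, known or untested is meant among the compounds shown, and "the series" means these compounds.

Compound 1, `C=CCN1CCC(c2noc(COc3ccc(/C=C/C(=O)NO)cc3)n2)CC1`, gives 66% in an assay on isolated protein for inhibition of protein deacetylase HDAC6 (Homo sapiens), read by fluorescence, with a stated time of 1 h, tested at 100 nM; a lower number here means less inhibition, a higher number more inhibition at the concentration tested (going by the name of the read-out).
Compound 2, `O=C(/C=C/c1ccc(OCc2nc(C3CCN(Cc4ccccc4)CC3)no2)cc1)NO`, gives 71% in this assay.
Compound 3, `C=CCN1CCC(c2noc(COc3ccc(CCC(=O)NO)cc3)n2)CC1`, gives 15% in this assay.

Between compound 1 and compound 2 the change is phenyl in place of vinyl on a saturated chain carbon bound to an amine nitrogen in a ring, and the step it made is a number 5 percentage points higher from compound 1 to compound 2 (within the scatter). The two cores differ in that compound 3 carries 2-(hydroxycarbamoyl)ethyl in place of 2-(hydroxycarbamoyl)ethenyl on an aromatic carbon, and that step is a number 51 percentage points lower from compound 1 to compound 3 (beyond the scatter), leaving compound 3 as the lowest of the three.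

Compound 4, `O=C(CCc1ccc(OCc2nc(C3CCN(Cc4ccccc4)CC3)no2)cc1)NO`, is not yet measured. It differs from compound 3 by phenyl in place of vinyl on a saturated chain carbon bound to an amine nitrogen in a ring, the same change as from compound 1 to compound 2, at the same place. For compound 4 the expected step is a number 4 percentage points higher from compound 3 to compound 4 (within the scatter). This expectation rests on a number 5 percentage points higher from compound 1 to compound 2 (within the scatter), a step within the scatter, so compound 3 is taken as the anchor. Compound 4 is thus estimated at 19%, expected between 5% and 35%.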

Compound 4, a percentage reported as inhibition, at one concentration (the size of the read-out at that concentration, not a potency): 22%
Beside the measured number, compound 4's estimate is 3 percentage points below it, within the range that was stated.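

In this assay, allyl to benzyl on the core of compound 3 gave a number 7 percentage points higher from compound 3 to compound 4 (within the scatter), and this agrees with the earlier step on the other core: the same change on two cores in this assay, a number 5 percentage points higher (within the scatter) from compound 1 to compound 2 and a number 7 percentage points higher (within the scatter) from compound 3 to compound 4, 2 percentage points apart, within the scatter of two such steps. The change from 2-(hydroxycarbamoyl)ethenyl to 2-(hydroxycarbamoyl)ethyl gave a number 49 percentage points lower from compound 2 to compound 4 (beyond the scatter), so it also carried over: the same change on two cores in this assay, a number 51 percentage points lower (beyond the scatter) from compound 1 to compound 3 and a number 49 percentage points lower (beyond the scatter) from compound 2 to compound 4, 2 percentage points apart, within the scatter of two such steps. Among these compounds, this covers only two cores and one concentration. Both phenyl steps lie within the scatter, so the data show no clear difference from that change on either core rather than a real gain.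

The compounds shown leave open whether these steps hold with a methyl or an acetyl group in place of allyl or benzyl. They also leave open what a longer chain or a carboxylic acid would do in place of the 2-(hydroxycarbamoyl)ethyl group.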